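The source may report more compounds than this note shows. Statements on the series, on what has been measured and on what is new or still open speak of the compounds shown alone.

Measured so far in a functional assay on isolated protein for inhibition of Glucose-dependent insulinotropic receptor (Rattus norvegicus), read by HTRF and cAMP accumulation; a lower number here means that less compound is needed, a higher number that more compound is needed for the effect:
compound 1 `Cc1nc(S(C)(=O)=O)ccc1Oc1ncnc(OC2CCN(C(=O)OC(C)F)CC2)c1F`: 315 nM
compound 2 `Cc1nc(S(C)(=O)=O)ccc1Oc1ncnc(OC2CCN(C(=O)SC(C)C)CC2)c1F`: 41.3 nM

Going by the values given here, compound 2 stands lowest of these two numbers; the only other compound, compound 1, lies a 7.6-fold lower number from compound 1 to compound 2 (0.88 log units; beyond the scatter) away. Compound 3 `Cc1nc(S(C)(=O)=O)ccc1Oc1ncnc(OC2CCN(C(=O)SC(C)(C)C)CC2)c1F` differs from compound 2 by methyl in place of hydrogen on a saturated chain carbon bound to two saturated chain carbons and a sulfur. Among the compounds with values here, the one measured step, from compound 1 to compound 2, exchanged the whole group on the carbonyl carbon and so bears on this change only loosely; no measured step adds a methyl on that chain. For compound 3 the expected step is therefore a 1.1-fold higher number from compound 2 to compound 3 (0.04 log units; within the scatter), not beyond the scatter, and its estimated value in this assay is 45 nM (range 15 nM to 135 nM).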

Compound 3, half-maximal effective concentration: 30.7 nM
The estimate for compound 3 lay 1.5-fold (0.17 log units) above the measured number; low and high end bracket the measured number.
By their numbers in this assay, from the lowest: compounds 3 and 2 (each within the scatter of the next); then compound 1.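

In this assay, going from isopropyl to tert-butyl on the sulfur gives only a small shift (a 1.3-fold lower number from compound 2 to compound 3 (0.13 log units; within the scatter)), so this chain carbon accepts the added methyl without a change that stands out from the scatter. The sulfur-linked tert-butyl group also holds the advantage over the group on the carbonyl carbon of compound 1 (a 10-fold lower number from compound 1 to compound 3 (1.01 log units; beyond the scatter)). No evidence on the cause of either step is at hand. From the compounds shown here alone, what a tert-butoxy group on the carbonyl carbon would give stays open, and with it how much of that step belongs to the sulfur. Going by these compounds, a cyclopentyl group on the sulfur is equally open.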